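This account rests on a few compounds, and the source may have more. Where it says the series, first, only, none or still open, it means among the compounds named here.

Measured so far in a functional assay on EL4 cells (Mus musculus) for inhibition, tested at 100 uM; a lower number here means less inhibition, a higher number more inhibition at the concentration tested (going by the name of the read-out):
compound 1 `[N-]=[N+]=Nc1nccc2c1ncn2[C@H]1C[C@H](O)[C@@H](CO)O1`: 13%
compound 2 `OC[C@H]1OC(n2cnc3c(Nc4ccccc4)nccc32)[C@H](O)[C@@H]1O`: 10%
compound 3 `CN(C)c1nccc2c1ncn2[C@H]1C[C@H](O)[C@@H](CO)O1`: < 5%, which is a limit of the assay and not a number.

Of the two numbers shown, compound 2 and compound 1 lie within the scatter of each other in this assay, so neither is set apart from the other; the third value is a limit (the limit of < 5% in this assay, at which 1 of the 3 values shown sits).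

Going by the values given here, the only measured step that differs in one place is a number at least 8 percentage points lower from compound 1 to compound 3 (that floor lies within the scatter), dimethylamino in place of azido on an aromatic carbon. Its floor lies within the scatter, so it shows no change of a size that can be trusted.

Compound 4 `OC[C@H]1OC(n2cnc3c(SCc4ccccc4)nccc32)[C@H](O)[C@@H]1O` differs from compound 2 by benzylsulfanyl in place of anilino on an aromatic carbon. Among the compounds with values here, no measured step involves anilino or benzylsulfanyl, and the one step that exists is small, so no movement beyond the scatter in this assay is expected here. The step of no change at the digits printed from compound 2 to compound 4 (within the scatter) is therefore estimated to stay within the scatter. For compound 4 in this assay an expected value of 10%, between 0% and 25%, is estimated.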

Compound 4, a percentage reported as inhibition, at one concentration (the size of the read-out at that concentration, not a potency): 30%
Beside the measured number, compound 4's estimate is 20 percentage points below it, outside the stated range (above it).
By their numbers in this assay, from the lowest: compounds 2 and 1 (each within the scatter of the next); then compound 4. At a limit, below all of these: compound 3.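

In this assay, benzylsulfanyl in place of anilino on the aromatic carbon next to the ring nitrogen gives a number 20 percentage points higher from compound 2 to compound 4 (beyond the scatter). Going by these compounds alone, this is the first step that lies beyond the scatter, so on the shared core of compound 2 and compound 4 this position responds to the group it carries. Both groups hold a six-membered aromatic ring of carbon only and differ in the link to that ring, and nothing measured here explains the step.

From the compounds shown here alone, the sulfur, the extra carbon of the link and the loss of the hydrogen-bond donor all change together, so their separate shares remain open. A benzylamino or a phenylsulfanyl group at this position would pull these apart, and whether a longer chain between sulfur and the aromatic ring moves the number further is also unsettled.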